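This account rests on a few compounds, and the source may have more. Where it says the series, first, only, none or still open, it means among the compounds named here.

Compound 1 `COc1ccc(-c2nc3cc(/C=C4\SC(=O)NC4=O)ccc3[nH]2)cc1OC` carries a methoxy group where compound 2 `COc1cc(-c2nc3cc(/C=C4\SC(=O)NC4=O)ccc3[nH]2)ccc1OCC(C)C` carries an isobutoxy group; the two are otherwise alike. In a functional assay on HeLa cells (Homo sapiens) for inhibition, read by MTT assay, with a stated time of 48 h (on this read-out higher numbers stand for weaker inhibition and lower numbers for stronger inhibition), compound 1 gives 7830 nM and compound 2 gives 5220 nM, so the change isopropyl in place of hydrogen on a saturated chain carbon bound to an oxygen on an aromatic ring brought a 1.5-fold lower number from compound 1 to compound 2 (0.18 log units; within the scatter). Compound 3 `COc1ccc(-c2nc3cc(/C=C4\SC(=O)N(Cc5cc(OC)c(OC)c(OC)c5)C4=O)ccc3[nH]2)cc1OC` differs from compound 1 in more than one place, and the difference between the two cores is not broken down here; in this assay compound 3 gives 320 nM, the lowest of the three numbers and well apart from both compound 1 and compound 2. Compound 4 `COc1cc(-c2nc3cc(/C=C4\SC(=O)N(Cc5cc(OC)c(OC)c(OC)c5)C4=O)ccc3[nH]2)ccc1OCC(C)C` is to be measured. It stands to compound 3 as compound 2 stands to compound 1, the change being (isopropyl in place of hydrogen on a saturated chain carbon bound to an oxygen on an aromatic ring), made at the very same kind of place, so it is the same change. Because the earlier step of a 1.5-fold lower number from compound 1 to compound 2 (0.18 log units; within the scatter) stayed within the usual scatter, the step of a 1.5-fold lower number from compound 3 to compound 4 (0.16 log units; within the scatter) is expected to be of similar small size, with the core of compound 3 as the starting point. The value expected for compound 4 in this assay is therefore 220 nM, most likely between 90 nM and 550 nM.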

Compound 4, half-maximal inhibitory concentration: 250 nM
Estimate against measurement, compound 4: 1.1-fold (0.06 log units) below; the measured number falls inside the stated range.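

In this assay, replacing the methoxy group with an isobutoxy group gives a 1.3-fold lower number from compound 3 to compound 4 (0.11 log units; within the scatter), so on the core of compound 3 this change again stays within the ordinary variation of the measurement. Set side by side, the two steps agree: the same change on two cores in this assay, a 1.5-fold lower number (0.18 log units; within the scatter) from compound 1 to compound 2 and a 1.3-fold lower number (0.11 log units; within the scatter) from compound 3 to compound 4, 1.2-fold (0.07 log units) apart, within the scatter of two such steps. This shows that the change carried over from one core to the other as a small step in these two pairs, but it does not show that the isobutoxy group truly strengthens inhibition on either core, and two pairs cannot establish a rule for the whole series.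

The compounds shown leave open whether another group in place of the isobutoxy group, such as a longer chain, a benzyloxy group or a chain ending in an amine, would shift the number beyond the scatter. They also leave open whether the same change would remain this small on a third core.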